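The source may report more compounds than this note shows. Statements on the series, on what has been measured and on what is new or still open speak of the compounds shown alone.

Measured compounds:
- compound 1, `OC[C@H]1O[C@@H](n2cnc3c(CSCc4ccccc4)ncnc32)[C@H](O)[C@@H]1O`, 10700 nM in a functional assay on HL-60 cells (Homo sapiens) for inhibition, with a stated time of 72 h; a higher number here means a weaker inhibitor, a lower number a stronger inhibitor
- compound 2, `OC[C@H]1O[C@@H](n2cnc3c(COc4ccccn4)ncnc32)[C@H](O)[C@@H]1O`, 12000 nM in this assay
- compound 3, `CN(Cc1ccccc1)Cc1ncnc2c1ncn2[C@@H]1O[C@H](CO)[C@@H](O)[C@H]1O`, 5600 nM in this assay

Compound 3 gives the lowest of the three numbers. Its nearest neighbour is compound 1, and that gap, a 1.9-fold lower number from compound 1 to compound 3 (0.28 log units; within the scatter), lies within the scatter; the gap to compound 2, a 2.1-fold lower number from compound 2 to compound 3 (0.33 log units; beyond the scatter), is a modest step beyond it. Compound 3 can therefore not be called the most potent of the set on these numbers alone.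

Compound 4, `COCc1ncnc2c1ncn2[C@@H]1O[C@H](CO)[C@@H](O)[C@H]1O`, differs from compound 3 in one place: methoxy in place of benzyl(methyl)amino on a saturated chain carbon bound to an aromatic carbon.

Among the compounds with values here, both measured steps that end at compound 3, a 1.9-fold lower number from compound 1 to compound 3 (0.28 log units; within the scatter) and a 2.1-fold lower number from compound 2 to compound 3 (0.33 log units; beyond the scatter), swap one group bearing a six-membered aromatic ring for another such group; none of the measured steps removes the ring altogether, as the change to compound 4 does. The two steps were small, and the third, a 1.1-fold higher number from compound 1 to compound 2 (0.05 log units; within the scatter), was within the scatter. Within the data shown here, the account has no direct precedent for a group as small as methoxy at this position, so the expectation is uncertain. Compound 4 is expected to give a somewhat higher number in this assay, a step of a 2.7-fold higher number from compound 3 to compound 4 (0.43 log units; beyond the scatter). The estimate for compound 4 is 15000 nM, with a range from 5000 nM to 50000 nM.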

Compound 4, half-maximal inhibitory concentration: 13000 nM
Compound 4: the middle estimate sits 1.2-fold (0.06 log units) above what was measured; measured number inside the range.
By their numbers in this assay, from the lowest: compounds 3, 1, 2 and 4 (each within the scatter of the next, the first and the last beyond it).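

In this assay this position tolerates losing the six-membered aromatic ring of carbon only, as methoxy in place of benzyl(methyl)amino gives only a modest step (a 2.3-fold higher number from compound 3 to compound 4 (0.37 log units; beyond the scatter)). Replacing the other two ring-bearing groups with methoxy gives no change that can be told from the scatter, whether benzylsulfanyl (a 1.2-fold higher number from compound 1 to compound 4 (0.08 log units; within the scatter)) or (pyridin-2-yl)oxy (a 1.1-fold higher number from compound 2 to compound 4 (0.03 log units; within the scatter)), so a ring on this saturated chain carbon is not required for a number in this range, and nothing available explains these results.

The compounds shown leave open whether a small amine such as dimethylamino would stay with benzyl(methyl)amino or with methoxy. They also leave open whether a longer chain such as butoxy, or a carboxylic acid on this carbon, would move the number at all.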